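This account rests on a few compounds, and the source may have more. Where it says the series, first, only, none or still open, it means among the compounds named here.

Compound 1 `Cc1ccc(-c2ccnc(C(=O)Nc3ccc(Oc4ccnc5[nH]ccc45)cc3)c2)cc1` gives > 10000 nM in a functional assay on MCF7 cells (Homo sapiens) for cytotoxicity, read by MTT assay, with a stated time of 72 h (on this read-out lower numbers stand for stronger inhibition and higher numbers for weaker inhibition), a limit of the assay rather than a number.
Compound 2 `O=C(Nc1ccc(Oc2ccnc3[nH]ccc23)cc1)c1cc(-c2ccccc2)ccn1` gives 3750 nM in this assay.
Compound 3 `O=C(Nc1ccc(Oc2ccnc3[nH]ccc23)c(F)c1)c1ccc(-c2ccccc2)cn1` gives 4390 nM in this assay.

Compounds 1 and 2 differ by methyl in place of hydrogen on an aromatic carbon, and this change gave an at least 2.6-fold higher number from compound 2 to compound 1 (0.42 log units; beyond the scatter). The value of compound 1 sits at the limit of > 10000 nM in this assay, at which 1 of the 3 values shown sits. How the core of compound 3 differs from that of compound 2 is not broken down here; their two values in this assay lie within the usual scatter of each other. Compound 4 `Cc1ccc(-c2ccc(C(=O)Nc3ccc(Oc4ccnc5[nH]ccc45)c(F)c3)nc2)cc1` has yet to be measured; it differs from compound 3 by methyl in place of hydrogen on an aromatic carbon, the same change as between compounds 2 and 1. A weakening step is expected, a 2.7-fold higher number from compound 3 to compound 4 (0.44 log units; beyond the scatter), resting on the measured at least 2.6-fold higher number from compound 2 to compound 1 (0.42 log units; beyond the scatter). Compound 4 is therefore estimated to give 12000 nM in this assay, between 5000 nM and 30000 nM, with a fair chance that only a limit is reported.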

Compound 4, half-maximal inhibitory concentration: 8020 nM
Beside the measured number, compound 4's estimate is 1.5-fold (0.18 log units) above it; the measured number falls inside the stated range.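

In this assay, methyl in place of hydrogen gave a 1.8-fold higher number from compound 3 to compound 4 (0.26 log units; within the scatter). Set beside the earlier step, this gives the following picture: the same change on two cores in this assay, an at least 2.6-fold higher number (0.42 log units; beyond the scatter) from compound 2 to compound 1 and a 1.8-fold higher number (0.26 log units; within the scatter) from compound 3 to compound 4; the limit leaves it open whether they differ. Only the earlier step lies beyond the scatter, and it ends at a limit of the assay rather than a number, so the compounds neither show that the change carries from one core to the other at the same size nor show that its size depends on the core: the limit of > 10000 nM in this assay, at which 1 of the 4 values shown sits.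

The compounds shown leave open what an amine, a carboxylic acid or a longer chain would do in place of the methyl. They also leave open whether any such group would behave alike on both cores.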